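Phenyl to pyridin-3-yl on the benzylidene arm

A few compounds are considered here, and "the series" means these few. Any claim that something is new, unique, unknown or untested is made for them only; others in the source may bear on it.

Measured so far:
compound 1 `CCOC(=O)C1=C(Nc2ccccc2)S/C(=C\c2ccccc2)C1=O` — 23.6%
compound 2 `CCOC(=O)C1=C(Nc2ccc(OC)cc2)S/C(=C\c2ccc[nH]2)C1=O` — < 10%

For the measured compounds named here, in a functional assay on MCF7 cells (Homo sapiens) for inhibition, read by MTT assay, with a stated time of 72 h, tested at 10 uM (on this read-out lower numbers stand for less inhibition and higher numbers for more inhibition at the one concentration tested (going by the name of the read-out)), compound 1 gives 23.6%, the only number in the set. Going by the values given here, compound 2 reaches only a limit of this assay, < 10%, so the limit of < 10% in this assay, at which 1 of the 2 values shown sits, applies and no step between the two can be sized. Compound 3 `CCOC(=O)C1=C(Nc2ccccc2)S/C(=C\c2cccnc2)C1=O` is not yet measured; it differs from compound 1 by pyridin-3-yl in place of phenyl on a double-bonded chain carbon bound to a double-bonded ring carbon. Without any measured step in this assay, no change beyond the usual scatter is expected from compound 1 to compound 3, and compound 3 is estimated at 22% (range 8% to 38%), a step of a number 1.6 percentage points lower from compound 1 to compound 3 (within the scatter).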

Compound 3, a percentage reported as inhibition, at one concentration (the size of the read-out at that concentration, not a potency): < 10%
Compound 3 ended at the assay's limit; the forecaster's own chance of this, stated with the estimate: 20%; middle value at least 12 percentage points away from the limit.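

On a double-bonded chain carbon bound to a double-bonded ring carbon, pyridin-3-yl in place of phenyl gives in this assay a step of a number at least 13.6 percentage points lower from compound 1 to compound 3 (beyond the scatter), so this position is not indifferent to a single ring nitrogen. Compound 3 sits at a limit of the assay, < 10%, which makes the step a minimum and not a full size. Phenyl remains the only group here with a number, and the floor now holds most of the series: the limit of < 10% in this assay, at which 2 of the 3 values shown sit.

As far as these compounds go, whether pyridin-4-yl behaves like pyridin-3-yl remains open. So does whether a phenyl carrying an amine or a carboxylic acid at this place rises above that limit.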